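The compounds below may be only part of what the source reports. "The series", "measured", "known", "first", "only" and "open" are said of these compounds alone.

Compound 1 `COc1cc(CSc2cc(Cl)c(-c3nc(-c4ccccc4)no3)cc2S(=O)(=O)NC(=N)NO)cc(OC)c1OC` gives 4370 nM in a functional assay on NCI-H460 cells (Homo sapiens) (on this read-out higher numbers stand for weaker inhibition of growth and lower numbers for stronger inhibition of growth), the highest of the two numbers measured, while compound 2 `N=C(NO)NS(=O)(=O)c1cc(-c2nc(-c3ccccc3)no2)c(Cl)cc1SCc1ccccc1` gives 1940 nM. Within the data shown here, the one measured step, a 2.3-fold lower number from compound 1 to compound 2 (0.35 log units; beyond the scatter), alters the group on the saturated chain carbon bound to sulfur and leaves the site changed here untouched. Compound 3 `COc1cc(CSc2cc(Cl)c(-c3nc(-c4ccc(Cl)cc4)no3)cc2S(=O)(=O)NC(=N)NO)cc(OC)c1OC` differs from compound 1 by chloro in place of hydrogen on an aromatic carbon. Among the measured compounds shown here, no measured step bears on this change, so nothing beyond the scatter is expected. The step expected is a 1.2-fold lower number from compound 1 to compound 3 (0.10 log units; within the scatter). Compound 3 is therefore estimated at 3500 nM, within a range from 1200 nM to 12000 nM.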

Compound 3, concentration for 50% growth inhibition: 2240 nM
For compound 3 the middle estimate is 1.6-fold (0.19 log units) above the measured one; the measured number falls inside the stated range.
By their numbers in this assay, from the lowest: compounds 2, 3 and 1 (each within the scatter of the next, the first and the last beyond it).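

In this assay, chloro in place of hydrogen on the phenyl of the 3-phenyl-1,2,4-oxadiazol-5-yl group gives a 2.0-fold lower number from compound 1 to compound 3 (0.29 log units; within the scatter). Among these compounds, this is the first reading at this site, para to a large group, and it shows that the 4-chlorophenyl group is accepted without a change that stands clear of the scatter. No evidence accounts for this reading.

Going by these compounds, whether an amine or a carboxylic acid on this carbon would be accepted likewise stays open. So does whether chloro here would give a similar step on compound 2.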